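Hydroxyl epimer in the biphenyl-triazole series

This account rests on a few compounds, and the source may have more. Where it says the series, first, only, none or still open, it means among the compounds named here.

Measured so far:
- compound 1, `O=C(N1CCC=C[C@H]1COCc1ccccc1)n1cc(-c2ccc(-c3ccccc3)cc2)nn1` — 100 nM
- compound 2, `O=C(N1C[C@H](O)C=C[C@@H]1COCc1ccccc1)n1cc(-c2ccc(-c3ccccc3)cc2)nn1` — 5.01 nM

In an assay on HEK293 cells for inhibition of Monoacylglycerol lipase ABHD6 (Homo sapiens), read by fluorescence (a lower number here means a stronger inhibitor, a higher number a weaker inhibitor), compound 2 holds the lower of the two numbers; compound 1 gives 100 nM, a gap beyond the scatter. Compound 3, `O=C(N1C[C@H](O)C=C[C@H]1COCc1ccccc1)n1cc(-c2ccc(-c3ccccc3)cc2)nn1`, is the next step: the two compounds have the same atoms and bonds and differ only in configuration as drawn: 1 of 2 stereo elements differ; a stereocentre at a saturated ring carbon is drawn R in compound 2 and S in compound 3. Among the compounds with values here, no step between two measured compounds covers a change of configuration alone, so the size of this step is unknown. The expectation is a moderate rise, a 3.0-fold higher number from compound 2 to compound 3 (0.48 log units; beyond the scatter), with wide uncertainty in both directions. Compound 3 is estimated at 15 nM, in the range 4 nM to 80 nM.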

Compound 3, half-maximal inhibitory concentration: 316 nM
Compound 3: the middle estimate sits 21-fold (1.32 log units) below what was measured; measured number outside the range, above it.
By their numbers in this assay, from the lowest: compound 2; then compound 1; then compound 3.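

In this assay, configuration at a single saturated ring carbon proves decisive, with a 63-fold higher number from compound 2 to compound 3 (1.80 log units; beyond the scatter). That change alone accounts for the whole step: the fact that compounds 2 and 3 differ only in the configuration as drawn Hydroxy in place of hydrogen on a saturated ring carbon is not favourable in itself, since it gives a 3.2-fold higher number from compound 1 to compound 3 (0.50 log units; beyond the scatter), so its value depends on the configuration around it.

The compounds shown leave open whether a methoxy or an amine in place of the hydroxy would follow the same dependence on configuration. They also do not show how the configuration preference would carry over to other groups on the core.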